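Chain length at the octyl amide of compound 1

This account rests on a few compounds, and the source may have more. Where it says the series, first, only, none or still open, it means among the compounds named here.

Measured in a functional assay on SW-620 cells (Homo sapiens) for cytotoxicity, read by MTT assay, with a stated time of 48 h; a lower number here means a stronger inhibitor, a higher number a weaker inhibitor:
- compound 1, `CCCCCCCCNC(=O)[C@@H](NC(=O)c1nccc2ccccc12)[C@@H](C)O`: 67800 nM
- compound 2, `CCCCCCCCNC(=O)[C@@H](NC(=O)/C=C/c1ccccc1)[C@@H](C)O`: 61400 nM
- compound 3, `CCCCCCCCCCCCNC(=O)[C@@H](NC(=O)c1cc2ccccc2n1C)[C@@H](C)O`: > 200000 nM

Compound 1 and compound 2 sit within the scatter of each other in this assay, so neither stands apart. For compound 3 the assay reports only a limit, > 200000 nM, which is the limit of > 200000 nM in this assay, at which 1 of the 3 values shown sits.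

Compound 4, `CCCCCCCCCCCCCCNC(=O)[C@@H](NC(=O)c1nccc2ccccc12)[C@@H](C)O`, differs from compound 1 by hexyl in place of hydrogen on a saturated chain carbon, eight bonds along the chain from an amide-type nitrogen. Among the compounds with values here, no measured pair isolates this change, so its size is open. Compound 3 carries a longer chain than compound 1 but also a different acyl group, so its limit cannot be read as a chain effect. For compound 4 a small step toward a higher number, not clearly beyond the scatter, is expected, a 1.6-fold higher number from compound 1 to compound 4 (0.21 log units; within the scatter); the estimate for compound 4 is 110000 nM, between 40000 nM and 250000 nM.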

Compound 4, half-maximal inhibitory concentration: 30400 nM
For compound 4 the middle estimate is 3.6-fold (0.56 log units) above the measured one, and the stated range ends above it.
By their numbers in this assay, from the lowest: compound 4; then compounds 2 and 1 (each within the scatter of the next). At a limit, above all of these: compound 3.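

In this assay, hexyl in place of hydrogen on a saturated chain carbon, eight bonds along the chain from an amide-type nitrogen, gives a 2.2-fold lower number from compound 1 to compound 4 (0.35 log units; beyond the scatter). Within the data shown here, this is the first isolated reading of this position, and the added carbons bring no loss in this assay. Nothing shown gives a cause for the step.

Going by these compounds, whether the trend continues with a still longer chain, or holds with the acyl group of compound 2, stays open. On these data alone, a chain ending in an amine or a carboxylic acid also remains unknown.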